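Methyl-for-Hydrogen Homologation: Working Notes on Compound 4

This account rests on a few compounds, and the source may have more. Where it says the series, first, only, none or still open, it means among the compounds named here.

Measured so far, in a functional assay on the whole organism (strain Swiss) with Mus musculus as the target, in the maximal electroshock model, with a stated time of 0.5 h, at a dose of 300 mg/kg by the intraperitoneal route; a lower number here means a weaker effect, a higher number a stronger effect of the compound at the dose given:
compound 1, `COc1cccc(N2CCN(C(=O)C(C)N3C(=O)CCC3=O)CC2)c1`, gives 50%
compound 2, `CCC(C(=O)N1CCN(c2cccc(OC)c2)CC1)N1C(=O)CCC1=O`, gives 0%
compound 3, `CC(C(=O)N1CCN(c2ccccc2C(F)(F)F)CC1)N1C(=O)CCC1=O`, gives 100%

Compound 1 and compound 2 share a core and differ in one place only, by methyl in place of hydrogen on a saturated chain carbon, two bonds along the chain from an amide-type nitrogen in a ring and a carbonyl carbon. That single change made a step of a number 50 percentage points lower from compound 1 to compound 2 (beyond the scatter), so in this assay the added methyl took the effect away entirely within this pair.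

Compound 3 stands highest of the three measured compounds, and its steps to compound 1 and to compound 2 both lie beyond the scatter. The difference between the core of compound 1 and the core of compound 3 is not broken down here.

Compound 4, `CCC(C(=O)N1CCN(c2ccccc2C(F)(F)F)CC1)N1C(=O)CCC1=O`, is not yet measured. It differs from compound 3 by methyl in place of hydrogen on a saturated chain carbon, two bonds along the chain from an amide-type nitrogen in a ring and a carbonyl carbon. The place of this change reads word for word the same as in the step from compound 1 to compound 2, so it is the same change, now made on the core of compound 3.

The step from compound 3 to compound 4 in this assay is expected to be a number 60 percentage points lower from compound 3 to compound 4 (beyond the scatter), because the same change gave a number 50 percentage points lower from compound 1 to compound 2 (beyond the scatter) on the other core. Going by the values given here, the expectation is hedged because compound 3 starts from 100%, leaving more room than compound 1 had, and only one prior instance of the change exists. For compound 4 the estimate in this assay is 40%, with an expected range from 0% to 90%.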

Compound 4, a percentage reported as activity, at one dose (the size of the read-out at that dose, not a potency): 25%
Compound 4: the middle estimate sits 15 percentage points above what was measured, within the range that was stated.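

The methyl-for-hydrogen change gives a number 75 percentage points lower from compound 3 to compound 4 (beyond the scatter) in this assay, so on both cores shown it lowers the read-out by more than the scatter. The direction of the change carries from one core to the other, but its size does not: the same change on two cores in this assay, a number 50 percentage points lower (beyond the scatter) from compound 1 to compound 2 and a number 75 percentage points lower (beyond the scatter) from compound 3 to compound 4, 25 percentage points apart, beyond the scatter of two such steps

This does not show that the smaller step is a fixed feature of the core of compound 1, since compound 2 ends at 0%, the bottom of the percentage read-out, and the step could not have been any larger; compound 3 likewise starts at 100%, the top of it, and these are read-outs at one dose rather than potencies, so two pairs support neither a general rule nor a reason for the gap.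

As far as these compounds go, it remains open how a longer chain such as propyl, or a more polar group such as hydroxymethyl, would read at this same place in this assay, and whether the loss of effect continues beyond ethyl. From the compounds shown here alone, it is also open whether the same change lowers the read-out on a core carrying chlorine or a nitrile in place of trifluoromethyl.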